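Pyridin-3-yl in place of methoxymethyl: notes on compound 4

A few compounds are considered here, and "the series" means these few. Any claim that something is new, unique, unknown or untested is made for them only; others in the source may bear on it.

In a functional assay on HeLa cells (Homo sapiens) for inhibition, with a stated time of 72 h (on this read-out lower numbers stand for an effect already at smaller amounts and higher numbers for an effect only at larger amounts of compound), compound 3 (`COCCNCc1ccc(OCc2ccc(Cl)nc2)c(OC)c1`) gives 97000 nM and compound 1 (`COc1cc(CNCc2ccccc2)ccc1OCc1ccc(Cl)nc1`) gives 90000 nM, so the two sit level within the scatter. Compound 2 (`COc1cc(CNCCCN(C)C)ccc1OCc1ccc(Cl)nc1`) stands well apart at 5000 nM.

Compound 4 (`COc1cc(CNCc2cccnc2)ccc1OCc1ccc(Cl)nc1`) carries pyridin-3-yl in place of methoxymethyl on a saturated chain carbon bound to an amine nitrogen.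

The closest guide is the exchange at that same place with phenyl, a 1.1-fold higher number from compound 1 to compound 3 (0.03 log units; within the scatter), a step within the scatter. The two large steps, an 18-fold lower number from compound 1 to compound 2 (1.26 log units; beyond the scatter) and a 19-fold higher number from compound 2 to compound 3 (1.29 log units; beyond the scatter), both involve the (dimethylamino) group of compound 2. Compound 4 lacks that group, so these steps bear on it only weakly. Going by the values given here, no measured compound carries pyridin-3-yl, which leaves the estimate uncertain.

No step beyond the scatter is expected in this assay, and the estimated change is a 1.6-fold lower number from compound 3 to compound 4 (0.21 log units; within the scatter). For compound 4 the expected value is 60000 nM, with an estimated range from 20000 nM to 130000 nM.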

Compound 4, half-maximal effective concentration: 5000 nM
Beside the measured number, compound 4's estimate is 12-fold (1.08 log units) above it; measured number outside the range, below it.
By their numbers in this assay, from the lowest: compounds 2 and 4 (each within the scatter of the next); then compounds 1 and 3 (each within the scatter of the next).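

In working terms, a low number at this place on a saturated chain carbon bound to an amine nitrogen does not depend on the (dimethylamino) group of compound 2, since pyridin-3-yl gives no change at the digits printed from compound 2 to compound 4 (within the scatter) in this assay. The same group gives a large gain over methoxymethyl (a 19-fold lower number from compound 3 to compound 4 (1.29 log units; beyond the scatter)) and over phenyl (an 18-fold lower number from compound 1 to compound 4 (1.26 log units; beyond the scatter)). A six-membered aromatic ring alone therefore does not set the number here, as compound 1 and compound 4 both carry one yet stand far apart. No measurement available for this series accounts for the gap between them.

Still open, going by these compounds, is whether pyridin-4-yl or pyridin-2-yl would hold the number of compound 4. Also open, on these data alone, is whether a saturated ring amine such as piperidin-4-yl would do the same at this place.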